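The source may report more compounds than this note shows. Statements on the series, on what has been measured and on what is new or still open speak of the compounds shown alone.

Measured in an ADME assay on RAW264.7 cells (Mus musculus) for cytotoxicity, read by MTT assay, with a stated time of 72 h, tested at 50 uM; a higher number here means a stronger effect of the compound at the concentration tested, a lower number a weaker effect:
- compound 1 `O=C(Cn1c(=O)oc2ccccc21)NCc1ccccn1` gives 37.3%
- compound 2 `O=C(Cn1c(=O)oc2cc(Cl)ccc21)NCc1ccco1` gives 27.8%
- compound 3 `O=C(Cn1c(=O)oc2cc(Cl)ccc21)Nc1ccccn1` gives 33%

Compound 3 stands with its number close to those of both neighbours: compound 1 sits within the scatter of it, and compound 2 sits within the scatter of it on the other side. Among the compounds with values here, the only single-point step in this set is a number 5.2 percentage points higher from compound 2 to compound 3 (within the scatter), a change that does not move the read-out beyond the scatter.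

Compound 4 `O=C(Cn1c(=O)oc2cc(Cl)ccc21)NCc1ccccn1` is compound 3 with (pyridin-2-yl)methyl in place of pyridin-2-yl on an amide-type nitrogen. Within the data shown here, no measured step shows this exact change, so the step from compound 2 to compound 3 is the only guide, and it was within the scatter. Compound 1 carries the same (pyridin-2-yl)methyl group and differs from compound 4 only in the chlorine on the shared core; its number and that of compound 3 lie within the scatter of each other. The step from compound 3 to compound 4 in this assay is therefore expected to be small, a number 2 percentage points higher from compound 3 to compound 4 (within the scatter), with no direction beyond the scatter. Compound 4 is estimated at 35%, in the range 22% to 48%.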

Compound 4, a percentage reported as inhibition, at one concentration (the size of the read-out at that concentration, not a potency): 36.2%
Beside the measured number, compound 4's estimate is 1.2 percentage points below it; low and high end bracket the measured number.
By their numbers in this assay, from the lowest: compounds 2, 3, 4 and 1 (each within the scatter of the next).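

In this assay, within the data shown here, (pyridin-2-yl)methyl in place of pyridin-2-yl on the amide-type nitrogen gives a number 3.2 percentage points higher from compound 3 to compound 4 (within the scatter), the first direct reading of this change at this position, and it does not separate the two compounds. Pyridin-2-yl in place of furan-2-yl on the saturated chain carbon gives a number 8.4 percentage points higher from compound 2 to compound 4 (within the scatter), and chloro in place of hydrogen on an aromatic carbon gives a number 1.1 percentage points lower from compound 1 to compound 4 (within the scatter), so neither of these changes separates its pair in this assay either. No supporting measurement bears on these readings.

Still open, from the compounds shown here alone, is whether an amine or a carboxylic acid on the group at the amide-type nitrogen, or a longer chain in place of the methyl of (pyridin-2-yl)methyl, would give a step beyond the scatter. Also open, going by these compounds, is whether methoxy in place of chloro on the shared core would do so.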